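Hydroxamate chain length across a shared core

The compounds below may be only part of what the source reports. "The series", "measured", "known", "first", "only" and "open" are said of these compounds alone.

The three measured compounds share one core and differ only in the chain that carries the hydroxamic acid. Compound 1 `Nc1ncnc2c1c(-c1cnc3[nH]ccc3c1)nn2CCCCCCCCC(=O)NO` and compound 2 `Nc1nc2cc(-c3nn(CCCCCCCCCC(=O)NO)c4ncnc(N)c34)ccc2o1` carry the longer chains; compound 3 `Nc1nc2cc(-c3nn(CCCCC(=O)NO)c4ncnc(N)c34)ccc2o1` carries the shortest. In an assay on isolated protein for inhibition of protein deacetylase HDAC6 (Homo sapiens), with a stated time of 15 min, tested at 1 uM (on this read-out higher numbers stand for more inhibition at the one concentration tested (going by the name of the read-out) and lower numbers for less inhibition), compound 1 gives 99.2%, compound 2 gives 98.2%, and compound 3 gives 95.1%. Compound 3 thus holds the lowest of the three numbers, yet both gaps to it are within the scatter, and the step of a number 3.1 percentage points lower from compound 2 to compound 3 (within the scatter) shows that a much shorter chain cannot be told apart from repeat noise on this read-out. Compound 4 `Nc1nc2cc(-c3nn(CCCCCC(=O)NO)c4ncnc(N)c34)ccc2o1` moves the chain of compound 3 back toward that of compound 2: (hydroxycarbamoyl)methyl in place of hydroxycarbamoyl on a saturated chain carbon, four bonds along the chain from an aromatic nitrogen. For the measured compounds named here, the one measured step that bears on this change is a number 3.1 percentage points lower from compound 2 to compound 3 (within the scatter), which covered a larger change of the same kind and stayed within the scatter, so no step beyond the scatter is expected in this assay here either. Compound 4 is therefore expected to give about 96.5%, within a range from 90% to 99.5%. The step this estimate implies, a number 1.4 percentage points higher from compound 3 to compound 4 (within the scatter), is expected to stay within the scatter.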

Compound 4, a percentage reported as inhibition, at one concentration (the size of the read-out at that concentration, not a potency): 97.8%
The estimate for compound 4 lay 1.3 percentage points below the measured number; low and high end bracket the measured number.
By their numbers in this assay, from the lowest: compounds 3, 4, 2 and 1 (each within the scatter of the next).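

In this assay, one added chain carbon gives a number 2.7 percentage points higher from compound 3 to compound 4 (within the scatter), while the much larger shortening from the chain of compound 2 gives a number 0.4 percentage points lower from compound 2 to compound 4 (within the scatter). With this further chain length on the shared core, compounds 2, 3 and 4 all stand within the scatter of one another, so the earlier single step was not an isolated result and no dependence on chain length can be read at this position at the one concentration tested. No measurement at hand offers an explanation for this flat result.

As far as these compounds go, whether chain length would separate these compounds at lower concentrations or in a potency read-out remains open. Also open, from the compounds shown here alone, is whether a shorter chain, or a carboxylic acid in place of the hydroxamic acid, would keep this level of inhibition.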